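Benzyl variation on the shared core: expectation for compound 4

The source may report more compounds than this note shows. Statements on the series, on what has been measured and on what is new or still open speak of the compounds shown alone.

In a functional assay on cells (Platelet, Homo sapiens) for inhibition (on this read-out lower numbers stand for stronger inhibition and higher numbers for weaker inhibition), compound 1 `CCOC(=O)c1ccc(-c2nn(Cc3ccccc3Cl)c3ccccc23)cc1` gives 230 nM. Compound 2 `CCOC(=O)c1ccc(-c2nn(Cc3ccc(F)cc3)c3ccccc23)cc1` gives 190 nM and compound 3 `CCOC(=O)c1ccc(-c2nn(Cc3ccccn3)c3ccccc23)cc1` gives 290 nM. The step of a 1.2-fold lower number from compound 1 to compound 2 (0.08 log units; within the scatter) and the step of a 1.3-fold higher number from compound 1 to compound 3 (0.10 log units; within the scatter) both fall within the scatter, so compound 1 cannot be set apart from either neighbour; the step of a 1.5-fold higher number from compound 2 to compound 3 (0.18 log units; within the scatter) is also within the scatter. Compound 4 `CCOC(=O)c1ccc(-c2nn(Cc3cccnc3)c3ccccc23)cc1` differs from compound 1 by pyridin-3-yl in place of 2-chlorophenyl on a saturated chain carbon bound to an aromatic nitrogen. For the measured compounds named here, the steps that bear on this are the exchange of the same 2-chlorophenyl for pyridin-2-yl, a 1.3-fold higher number from compound 1 to compound 3 (0.10 log units; within the scatter), and for 4-fluorophenyl, a 1.2-fold lower number from compound 1 to compound 2 (0.08 log units; within the scatter), neither beyond the scatter. No step beyond the scatter is therefore expected in this assay; the expected change is a 1.1-fold higher number from compound 1 to compound 4 (0.05 log units; within the scatter). Compound 4 is estimated at 260 nM, with a range from 120 nM to 560 nM.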

Compound 4, half-maximal inhibitory concentration: 5550 nM
Beside the measured number, compound 4's estimate is 21-fold (1.33 log units) below it; measured number above the stated range.
By their numbers in this assay, from the lowest: compounds 2, 1 and 3 (each within the scatter of the next); then compound 4.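

In this assay the place on a saturated chain carbon bound to an aromatic nitrogen does not accept every aromatic ring equally: pyridin-3-yl gives a large loss against 2-chlorophenyl (a 24-fold higher number from compound 1 to compound 4 (1.38 log units; beyond the scatter)) and against 4-fluorophenyl (a 29-fold higher number from compound 2 to compound 4 (1.47 log units; beyond the scatter)). The exchange of pyridin-2-yl for pyridin-3-yl alone also gives a large step (a 19-fold higher number from compound 3 to compound 4 (1.28 log units; beyond the scatter)), so a ring nitrogen as such does not set the loss; which pyridine isomer is present does.

No data here explain the gap between the two pyridines.

From the compounds shown here alone, whether pyridin-4-yl on the same carbon would follow compound 3 or compound 4 remains open.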